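Hepatocyte stability of the series: one number so far

The source may report more compounds than this note shows. Statements on the series, on what has been measured and on what is new or still open speak of the compounds shown alone.

Measured in an ADME assay on cells (Hepatocyte, Homo sapiens) for metabolic stability, read by LC-MS, with a stated time of 60 min (a lower number here means that less of the compound is left, a higher number that more of the compound is left), so far:
compound 1 `C[C@@H]1CC(c2cnc3c(C#N)nn([C@H](C)c4ccc(Cl)cc4Cl)c3n2)=CC[C@@H]1N1CCC[C@H]1C(C)(C)O` gives "not determined" (no result reported)
compound 2 `C[C@@H]1CC(c2cnc3c(C#N)nn([C@H](C)c4ccc(Cl)cc4Cl)c3n2)=CC[C@@H]1N1CCC[C@H]1C` gives 86%

Among the compounds with values here, compound 2 holds the only number, so it has no measured neighbour to stand against. Compound 3 `C[C@@H]1CC(c2cnc3c(C#N)nn([C@H](C)c4ccc(Cl)cc4Cl)c3n2)=CC[C@@H]1N1CCC[C@H]1C(N)=O` has carbamoyl in place of methyl on a saturated ring carbon and is still unmeasured. Within the data shown here, no measured pair differs in one place, so the data give no guide to the size of this change. In this assay the estimated step of a number 4 percentage points lower from compound 2 to compound 3 (within the scatter) is not expected to go beyond the scatter in either direction. For compound 3 the expected value is 82% with an estimated range from 66% to 95% in this read-out.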

Compound 3, percent of the compound remaining: 97%
Beside the measured number, compound 3's estimate is 15 percentage points below it; the measured number lies above the stated range.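

In this assay, within the data shown here, the step of a number 11 percentage points higher from compound 2 to compound 3 (beyond the scatter) gives the first measured reading at this place: on the saturated ring carbon next to the ring nitrogen, carbamoyl is compatible with more compound remaining than methyl. So the larger group, which brings a hydrogen-bond donor and acceptor, costs nothing in this read-out for this pair. Nothing at hand bears on the reason for this step.

As far as these compounds go, it remains open whether the step is particular to carbamoyl or extends to a carboxylic acid, an amine or a longer chain on the same carbon. From the compounds shown here alone, whether it carries over to other changes on the shared core also remains open.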